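Fluoro to bromo on the shared core

This account rests on a few compounds, and the source may have more. Where it says the series, first, only, none or still open, it means among the compounds named here.

Measured in a functional assay on DU-145 cells (Homo sapiens) for cytotoxicity, read by XTT assay, with a stated time of 24 h; on this read-out lower numbers stand for stronger inhibition and higher numbers for weaker inhibition:
- compound 1 `COc1cc(C)c(Cl)c2c1C(=O)C=CC2=O`: 26600 nM
- compound 2 `Cc1cc(O)c2c(c1Cl)C(=O)C=CC2=O`: 29500 nM
- compound 3 `Cc1cc(O)c2c(c1F)C(=O)C=CC2=O`: 15400 nM

Compound 3, at 15400 nM, lies within the scatter of both other compounds, so these three cannot be ranked. Compound 4 `Cc1cc(O)c2c(c1Br)C(=O)C=CC2=O` differs from it by bromo in place of fluoro on an aromatic carbon, para to a hydroxy group. The closest measured change is fluoro in place of chloro at that same spot, a 1.9-fold lower number from compound 2 to compound 3 (0.28 log units; within the scatter). The other measured change, a 1.1-fold higher number from compound 1 to compound 2 (0.04 log units; within the scatter), concerns the oxygen instead. With this evidence, no step beyond the scatter is expected in this assay, at most a small drift towards a higher number. The expected change is a 1.4-fold higher number from compound 3 to compound 4 (0.15 log units; within the scatter). Compound 4 is estimated at 22000 nM, with an expected range of 11000 nM to 44000 nM.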

Compound 4, half-maximal inhibitory concentration: 46300 nM
For compound 4 the middle estimate is 2.1-fold (0.32 log units) below the measured one; the measured number lies above the stated range.
By their numbers in this assay, from the lowest: compounds 3, 1, 2 and 4 (each within the scatter of the next, the first and the last beyond it).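

At this spot, para to a hydroxy group, the choice of halogen does register in this assay, with a 3.0-fold higher number from compound 3 to compound 4 (0.48 log units; beyond the scatter), the first step among these compounds to pass beyond the scatter. Chloro cannot be placed in order against bromo, with a 1.6-fold higher number from compound 2 to compound 4 (0.20 log units; within the scatter), so only the fluoro and bromo compounds are told apart here. Nothing measured here gives a reason for the step.

On these data alone, an amine or a nitrile at this spot remains open. So does whether fluoro and bromo differ likewise on the core of compound 1, with its methyl on the oxygen.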